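Replacing a nitrofuran amide with a cyclohexyl urea

The source may hold more compounds than are shown below. What is called first, only, known or untested is meant among the compounds shown, and "the series" means these compounds.

Two compounds share one core and differ only in the group attached to a carbonyl carbon. Compound 1 `O=C(c1cc(Cl)nc(Cl)c1)N1CCc2cc(S(=O)(=O)N3C[C@H](c4ccccc4)NC3=O)ccc21` carries a 2,6-dichloropyridin-4-yl there; in a functional assay on HCT-116 cells (Homo sapiens) for inhibition (a higher number here means a weaker inhibitor of growth, a lower number a stronger inhibitor of growth), compound 1 gives 380 nM. Compound 2 `O=C(c1ccc([N+](=O)[O-])o1)N1CCc2cc(S(=O)(=O)N3C[C@H](c4ccccc4)NC3=O)ccc21` carries a 5-nitrofuran-2-yl instead, and in this assay compound 2 gives 270 nM. Going by the values given here, the single measured step, a 1.4-fold lower number from compound 1 to compound 2 (0.15 log units; within the scatter), stays within the usual scatter, so compound 2 stands alongside compound 1 rather than apart from it.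

Compound 3 `O=C(NC1CCCCC1)N1CCc2cc(S(=O)(=O)N3C[C@H](c4ccccc4)NC3=O)ccc21` has not been measured. It differs from compound 2 as follows: cyclohexylamino in place of 5-nitrofuran-2-yl on a carbonyl carbon. Among the compounds with values here, the only measured step swapped one aromatic group for another on that carbonyl carbon and changed little; it bears on the new change only loosely, since cyclohexylamino is neither aromatic nor a bearer of acceptors. Within the data shown here, no step here shows what such a change does, so the expectation rests on a wide range rather than a direction. Compound 3 is estimated at 500 nM in this assay, with a range from 150 nM to 2500 nM, which means an expected step of a 1.9-fold higher number from compound 2 to compound 3 (0.27 log units; within the scatter).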

Compound 3, concentration for 50% growth inhibition: 50 nM
The estimate for compound 3 lay 10-fold (1.00 log units) above the measured number; the whole stated range lies above it.
By their numbers in this assay, from the lowest: compound 3; then compounds 2 and 1 (each within the scatter of the next).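

In this assay, the group on this carbonyl carbon turns out to matter: the two aromatic groups gave values within the scatter of each other, whereas cyclohexylamino gives a 5.4-fold lower number from compound 2 to compound 3 (0.73 log units; beyond the scatter) and a 7.6-fold lower number from compound 1 to compound 3 (0.88 log units; beyond the scatter), both beyond the scatter. A low number at this place therefore does not need an aromatic ring, since compound 3 carries a six-membered non-aromatic ring of carbon only and has the lowest number of the three, while the core stays the same. No measurement at hand explains why this swap lowers the number.

The compounds shown leave open whether the lower number goes with the amino nitrogen and its hydrogen or with the carbon-only ring, as the swap from compound 2 to compound 3 changes both at once. A phenylamino group, which keeps that nitrogen but restores an aromatic ring, and a cyclohexyl group bonded straight to the carbonyl carbon, which keeps the ring but drops the nitrogen, would pull these two features apart.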